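The source may report more compounds than this note shows. Statements on the series, on what has been measured and on what is new or still open speak of the compounds shown alone.

Measured in a functional assay on SW480 cells (Homo sapiens) for antiproliferative activity, read by MTT assay, with a stated time of 48 h; on this read-out lower numbers stand for stronger inhibition and higher numbers for weaker inhibition:
Compound 1 `CCCCCCCC(CCO)n1cnc2c(OC)ncnc21` gives 23900 nM
Compound 2 `CCCCCCCC(CCO)n1cnc2c(N)ncnc21` gives > 50000 nM, which is a limit of the assay

Among the compounds with values here, compound 1, at 23900 nM, holds the only actual number so far. Compound 3 `CCCCCCCCCCC(CCO)n1cnc2c(OC)ncnc21` differs from compound 1 by propyl in place of hydrogen on a saturated chain carbon, eight bonds along the chain from an aromatic nitrogen. Within the data shown here, the one measured step, an at least 2.0-fold higher number from compound 1 to compound 2 (0.32 log units; beyond the scatter), is amino in place of methoxy on an aromatic carbon and leaves the chain untouched, so it gives no direct measure for this change. A modest move towards lower numbers in this assay is nevertheless expected, though it could stay within the scatter. The expected step is a 2.0-fold lower number from compound 1 to compound 3 (0.30 log units; within the scatter). For compound 3 the estimate is 12000 nM, with an expected range of 4000 nM to 40000 nM.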

Compound 3, half-maximal inhibitory concentration: 8260 nM
The estimate for compound 3 lay 1.5-fold (0.16 log units) above the measured number, and the stated range covers the measured number.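

In this assay the chain proves responsive: propyl in place of hydrogen, eight bonds along the chain from an aromatic nitrogen, gives a 2.9-fold lower number from compound 1 to compound 3 (0.46 log units; beyond the scatter) and so moves the number by more than the usual scatter. The earlier step changed only the methoxy group and said nothing about the chain. Nothing shown accounts for the size of this step.

Going by these compounds, whether a longer chain would lower the number further remains open. So does the effect of a carboxylic acid on the chain, or of amino in place of methoxy on the longer chain.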